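The source may report more compounds than this note shows. Statements on the series, on what has been measured and on what is new or still open speak of the compounds shown alone.

Compound 3 `CCCNS(=O)(=O)c1ccc(Nc2ncc3c(n2)N(C2CCCC2)[C@H](CC)C(=O)N3C)cc1` gives 17.8 nM in an assay for inhibition of serine/threonine-protein kinase PLK2 (Homo sapiens), read by FRET and Z'-LYTE, with a stated time of 1 h; on this read-out higher numbers stand for weaker inhibition and lower numbers for stronger inhibition. Compound 2 `CCCCNS(=O)(=O)c1ccc(Nc2ncc3c(n2)N(C2CCCC2)[C@H](CC)C(=O)N3C)cc1` gives 19.9 nM in this assay. The two differ by one change, (methyl in place of hydrogen on a saturated chain carbon, three bonds along the chain from a sulfonamide nitrogen), and that change produced a 1.1-fold higher number from compound 3 to compound 2 (0.05 log units; within the scatter), a step that is within the usual scatter of repeated runs.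

Compound 1 `CCCNS(=O)(=O)c1ccc(Nc2ncc3c(n2)N(c2ccn(C)n2)C(CC)C(=O)N3C)cc1` gives 190 nM in this assay, the highest of the three measured numbers; its value stands a good deal above that of compound 2 and that of compound 3, and both gaps are beyond the scatter. The difference between the core of compound 1 and the core of compound 3 is not broken down here.

Compound 4 `CCCCNS(=O)(=O)c1ccc(Nc2ncc3c(n2)N(c2ccn(C)n2)C(CC)C(=O)N3C)cc1` has not yet been measured in this assay. It differs from compound 1 by methyl in place of hydrogen on a saturated chain carbon, three bonds along the chain from a sulfonamide nitrogen, the same change, at the same place, that separates compound 3 from compound 2. Because that change gave only a 1.1-fold higher number from compound 3 to compound 2 (0.05 log units; within the scatter), the same kind of small step is expected from compound 1 to compound 4, namely a 1.1-fold higher number from compound 1 to compound 4 (0.04 log units; within the scatter). Compound 4 is therefore expected to give about 210 nM in this assay, with a likely range from 100 nM to 450 nM.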

Compound 4, half-maximal inhibitory concentration: 191 nM
For compound 4 the middle estimate is 1.1-fold (0.04 log units) above the measured one; low and high end bracket the measured number.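

On the core of compound 1, methyl in place of hydrogen on a saturated chain carbon, three bonds along the chain from a sulfonamide nitrogen, gave a 1.0-fold higher number from compound 1 to compound 4 (0.00 log units; within the scatter) in this assay. Set beside the earlier step, the change carried from one core to the other with no difference that stands out from the scatter: the same change on two cores in this assay, a 1.1-fold higher number (0.05 log units; within the scatter) from compound 3 to compound 2 and a 1.0-fold higher number (0.00 log units; within the scatter) from compound 1 to compound 4, 1.1-fold (0.05 log units) apart, within the scatter of two such steps. This shows that propyl to butyl left the read-out unchanged within the scatter on these two cores, but it does not show that the same would hold on any other core, and it says nothing about the gap between the core of compound 1 and the core of compound 3.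

Going by these compounds, it remains open whether a longer chain such as pentyl, or a chain ending in an amine or a carboxylic acid, would behave as the butyl chain does. On these data alone, a shorter chain such as ethyl is equally open on either core.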